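This account rests on a few compounds, and the source may have more. Where it says the series, first, only, none or still open, it means among the compounds named here.

Measured compounds in an assay on isolated protein for inhibition of complement C1r subcomponent (Homo sapiens); a higher number here means a weaker inhibitor, a lower number a stronger inhibitor:

- compound 1, `O=c1oc(Nc2cc(Cl)ccc2Cl)nc2ccccc12`: 2000 nM
- compound 2, `O=c1oc(Nc2nccs2)nc2ccccc12`: reported only as a limit, > 62500 nM
- compound 3, `O=c1oc(Nc2ccccc2I)nc2ccc(Cl)cc12`: 4000 nM

Compound 2 sits at the limit of this assay, (the limit of > 62500 nM in this assay, at which 1 of the 3 values shown sits), so it gives no number to compare against. Of the two numbers shown, compound 3 and compound 1 lie within the scatter of each other, so no order between them can be read; compound 3 has the higher printed value, but that says nothing beyond the scatter.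

Compound 4 is `O=c1oc(Nc2ccccc2I)nc2cc(Cl)c(Cl)cc12` and has not yet been measured. It differs from compound 3 by chloro in place of hydrogen on an aromatic carbon. Among the measured compounds shown here, no step between measured compounds touches this position, so there is nothing that fixes the size or direction of the change. With the variation at the aniline part between compound 1 and compound 3 already staying within the scatter, the expectation is a step from compound 3 to compound 4 of no more than the scatter itself, with no clear direction, a 1.3-fold lower number from compound 3 to compound 4 (0.12 log units; within the scatter). The estimate for compound 4 in this assay is therefore 3000 nM, within a range from 1000 nM to 10000 nM.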

Compound 4, half-maximal inhibitory concentration: 500 nM
Compound 4: middle estimate off by 6.0-fold (0.78 log units), on the high side, outside the stated range (below it).
By their numbers in this assay, from the lowest: compound 4; then compounds 1 and 3 (each within the scatter of the next). At a limit, above all of these: compound 2.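

In this assay, among the compounds shown here, chloro in place of hydrogen on an aromatic carbon gives an 8.0-fold lower number from compound 3 to compound 4 (0.90 log units; beyond the scatter), the first step that can be read at a single position, and one that lies beyond the scatter. For the compounds shown here, the position is on a six-membered aromatic ring of carbon only, ortho to a chloro group, meta to a fused ring and para to a fused ring, and the earlier compounds gave no sign that it mattered; the change adds only one chlorine atom, with no ring, no hydrogen-bond donors or acceptors and no net charge, so this position responds to a very small substitution, at least with the 2-iodo aniline part of compound 3 in place. No measured property among the data shown bears on why this step has this size.

Going by these compounds alone, only this one pair speaks for the position, so it stays open whether the same gain would appear with the 2,5-dichloro aniline part of compound 1 or with no chloro group at the neighbouring carbon. Going by these compounds, it is also open whether fluoro, bromo, methyl, methoxy, nitrile or an amine at this carbon would move the number in the same direction, or by a similar amount.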